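The source may report more compounds than this note shows. Statements on the series, on what has been measured and on what is new or still open speak of the compounds shown alone.

Among the measured compounds shown here, compound 3 `Cc1ccc(CS(=O)(=O)/C(=C/c2ccc(N(C)C)cc2)C(=O)c2ccc(Cl)cc2)cc1` gives 50000 nM in a functional assay on DU-145 cells (Homo sapiens) for inhibition, read by trypan blue exclusion, with a stated time of 96 h (a higher number here means a weaker inhibitor of growth, a lower number a stronger inhibitor of growth), the highest of the three numbers so far; compound 1 `CSc1ccc(/C=C(\C(=O)c2ccc(Cl)cc2)S(=O)(=O)Cc2ccc(C)cc2)cc1` gives 10000 nM and compound 2 `Cc1ccc(CS(=O)(=O)/C(=C/c2cc(C)cc(C)c2)C(=O)c2ccc(Cl)cc2)cc1` gives 10000 nM, each a step beyond the scatter lower than compound 3. Compound 4 `Cc1ccc(CS(=O)(=O)/C(=C/c2cc(C)ccc2C)C(=O)c2ccc(Cl)cc2)cc1` differs from compound 3 in one place: 2,5-dimethylphenyl in place of 4-(dimethylamino)phenyl on a double-bonded chain carbon bound to a double-bonded chain carbon. For the measured compounds named here, two measured steps bear on this change. Loss of the dimethylamino group reverses a 5.0-fold higher number from compound 2 to compound 3 (0.70 log units; beyond the scatter), and the same group exchange gave a 5.0-fold higher number from compound 1 to compound 3 (0.70 log units; beyond the scatter); between compounds 1 and 2, no change at the digits printed from compound 1 to compound 2 (within the scatter). Compound 4 is therefore expected to show a 5.0-fold lower number from compound 3 to compound 4 (0.70 log units; beyond the scatter) in this assay, returning to the level seen for compound 2. The estimate for compound 4 is 10000 nM, with a range from 4000 nM to 25000 nM.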

Compound 4, concentration for 50% growth inhibition: 1000 nM
Estimate against measurement, compound 4: 10-fold (1.00 log units) above, outside the stated range (below it).
By their numbers in this assay, from the lowest: compound 4; then compounds 1 and 2 (each within the scatter of the next); then compound 3.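

In this assay, 2,5-dimethylphenyl at this place on the double-bonded chain carbon gives a 50-fold lower number from compound 3 to compound 4 (1.70 log units; beyond the scatter) and a 10-fold lower number from compound 1 to compound 4 (1.00 log units; beyond the scatter) and, most tellingly, a 10-fold lower number from compound 2 to compound 4 (1.00 log units; beyond the scatter) for a change in methyl placement alone. The earlier exchange of 4-(methylsulfanyl)phenyl for 3,5-dimethylphenyl gave no such separation, so the arrangement of the ring substituents here can matter as much as their identity. No measurement shown accounts for this shift.

Open, going by these compounds, is whether 2-methylphenyl or 3-methylphenyl keeps the low number of compound 4. Also open, on these data alone, is how 2,5-dimethoxyphenyl or 2,5-dichlorophenyl would behave at this place.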